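This account rests on a few compounds, and the source may have more. Where it says the series, first, only, none or still open, it means among the compounds named here.

Measured so far:
- compound 1 `COc1cc(OC(F)(F)F)ccc1Nc1nc2nonc2nc1O` gives 3800 nM
- compound 2 `CCCCCCc1ccc(Nc2nc3nonc3nc2O)c(F)c1` gives 3300 nM

Both numbers come from an assay on mitochondria from L6 cells (Rattus norvegicus) for activation, with a stated time of 90 min; on this read-out lower numbers stand for an effect already at smaller amounts and higher numbers for an effect only at larger amounts of compound. Compound 2 has the lowest of the two numbers, but its nearest neighbour, compound 1, sits within the usual scatter of this assay, so the two cannot be told apart on these data. Both compounds share the same core and differ only in the groups carried on their aromatic ring.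

Compound 3 `Oc1nc2nonc2nc1Nc1ccc(OC(F)(F)F)cc1F` has not been measured yet. It comes from compound 2 by a single change: trifluoromethoxy in place of hexyl on an aromatic carbon. For the measured compounds named here, no measured pair shows this exact step, so its size is unknown here. Compound 1, which also carries a trifluoromethoxy group, gives 3800 nM, a number within the scatter of compound 2. On that basis the step from compound 2 to compound 3 is expected to be small, a 1.4-fold higher number from compound 2 to compound 3 (0.13 log units; within the scatter), with no clear direction beyond the scatter. Compound 3 is therefore estimated to give 4500 nM in this assay, with a plausible range from 1500 nM to 13000 nM.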

Compound 3, half-maximal effective concentration: 2300 nM
For compound 3 the middle estimate is 2.0-fold (0.29 log units) above the measured one, within the range that was stated.
By their numbers in this assay, from the lowest: compounds 3, 2 and 1 (each within the scatter of the next).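

In this assay, for the compounds shown here, compounds 1 and 2 alone offered no pair differing in one place, and compound 3 now supplies two such pairs. Trifluoromethoxy in place of hexyl on this aromatic carbon gives a 1.4-fold lower number from compound 2 to compound 3 (0.16 log units; within the scatter), so these two quite different groups, one a plain carbon chain and the other holding oxygen and fluorine, cannot be told apart at this position, and the same holds for fluoro in place of methoxy on the other changed aromatic carbon, which gives a 1.7-fold lower number from compound 1 to compound 3 (0.22 log units; within the scatter). Neither step lies beyond the usual scatter, and nothing at hand offers an explanation for how close these numbers stay.

Going by these compounds, three compounds cover only a narrow set of groups, so it remains open whether an amine, a carboxylic acid or a longer chain on the carbon that carries hexyl or trifluoromethoxy would produce a step beyond the scatter. On these data alone, it also remains open whether a chloro group or a methyl group in place of the fluoro or methoxy group would do so, or whether this read-out stays just as flat there.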